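The source may hold more compounds than are shown below. What is called first, only, known or untested is meant among the compounds shown, and "the series" means these compounds.

Measured so far:
- compound 1 `Cc1cc(CCC(=O)O)ccc1-c1noc(-c2ccc(OC(C)C)c(C#N)c2)n1` gives 13 nM in a functional assay for agonist activity at sphingosine 1-phosphate receptor 5 (Homo sapiens), read by GTPgammaS binding; a higher number here means that more compound is needed for the effect, a lower number that less compound is needed
- compound 2 `Cc1cc(CCC(=O)O)ccc1-c1ncc(-c2ccc(OC(C)C)c(C#N)c2)s1` gives 120 nM in this assay

Among these two numbers compound 2 stands highest; the only neighbour is compound 1, whose number is lower by a margin beyond the scatter. Compound 3 `Cc1cc(CCC(=O)O)ccc1-c1nc(C)c(-c2ccc(OC(C)C)c(C#N)c2)s1` differs from compound 2 by one change: methyl in place of hydrogen on an aromatic carbon, a methyl in place of hydrogen on an aromatic carbon. Among the compounds with values here, no measured pair shows what this change does, so the expected step of a 1.7-fold lower number from compound 2 to compound 3 (0.23 log units; within the scatter) is set small and toward a lower number, with wide uncertainty. Compound 3 is therefore estimated at 70 nM, between 15 nM and 300 nM.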

Compound 3, half-maximal effective concentration: > 10000 nM
Compound 3 gave a limit, no number; the forecaster's own chance of this, stated with the estimate: 3%; middle value at least 140-fold (2.15 log units) from the limit.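

In this assay, this place on the five-membered ring, next to the ring nitrogen, proves highly sensitive to substitution: a methyl in place of hydrogen gives an at least 83-fold higher number from compound 2 to compound 3 (1.92 log units; beyond the scatter). Compound 3 stands as a limit of the assay, not a number: the limit of > 10000 nM in this assay, at which 1 of the 3 values shown sits. Within the data shown here, compound 1 and compound 2 carry no group at this place, so this is the first view of what a single added carbon does here. Still open, going by these compounds, is whether fluorine, an amine or a methoxy group at this place would fare the same way as methyl.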